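The source may report more compounds than this note shows. Statements on the series, on what has been measured and on what is new or still open speak of the compounds shown alone.

Measured so far:
compound 1, `CCCCCc1c(C(C)C)nc(C(C)C)c(CO)c1-c1ccc(F)cc1F`: 11000 nM
compound 2, `CCCCCc1c(C(C)C)nc(C(C)C)c(CO)c1-c1cccc(O)c1`: 6000 nM

In an assay on CHO cells for inhibition of Glucagon receptor (Homo sapiens) (a higher number here means a weaker inhibitor, a lower number a stronger inhibitor), compound 1 gives 11000 nM, and compound 2 gives 6000 nM. Of these two numbers, that of compound 2 is the smaller, yet the step of a 1.8-fold lower number from compound 1 to compound 2 (0.26 log units; within the scatter) lies within the scatter, so the two compounds cannot really be told apart on the numbers shown.

Compound 3, `CCCCCc1c(C(C)C)nc(C(C)C)c(CO)c1-c1cccc(OC)c1`, has not yet been measured. It differs from compound 2 in one place: methyl in place of hydrogen on an oxygen on an aromatic ring, that is, hydroxy becomes methoxy and 3-hydroxyphenyl becomes 3-methoxyphenyl. For the measured compounds named here, no measured pair shows this change. Going by the values given here, the only measured step, a 1.8-fold lower number from compound 1 to compound 2 (0.26 log units; within the scatter), exchanges the whole aromatic group and bears only loosely on adding a methyl to the oxygen; it was itself within the scatter. With nothing pointing in either direction, the expectation for this assay is a step no larger than the scatter, no change at the digits printed from compound 2 to compound 3 (within the scatter). Compound 3 is therefore estimated at 6000 nM, with a range from 2500 nM to 15000 nM.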

Compound 3, half-maximal inhibitory concentration: 48000 nM
Estimate against measurement, compound 3: 8.0-fold (0.90 log units) below; the measured number lies above the stated range.
By their numbers in this assay, from the lowest: compounds 2 and 1 (each within the scatter of the next); then compound 3.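

In this assay, for the compounds shown here, the oxygen on the aromatic ring is the first place where a single small change moves the number beyond the scatter: methyl in place of hydrogen gives an 8.0-fold higher number from compound 2 to compound 3 (0.90 log units; beyond the scatter). So a hydroxy and a methoxy group are not interchangeable here, even though the change adds only one heavy atom. The exchange of the whole aromatic group, which could not be told apart from the scatter in the earlier pair, now also gives a readable difference once that group is 3-methoxyphenyl in place of 2,4-difluorophenyl, with a 4.4-fold higher number from compound 1 to compound 3 (0.64 log units; beyond the scatter), and no measurement at hand explains either step.

The compounds shown leave open whether the higher number goes with losing the hydrogen on the oxygen or with adding the methyl, and an amine or an ethoxy group in that place would help to separate the two readings. They also leave open whether a group that differs more widely, such as a carboxylic acid on the same aromatic ring, would bring the number below that of compound 2.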